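Extending a Side Chain by One Carbon

The source may hold more compounds than are shown below. What is called first, only, known or untested is meant among the compounds shown, and "the series" means these compounds.

Compound 1 `CC(C)(C)OC(=O)NCCC[C@@H]1N=C2C[C@@H]3C[C@@H](C3(C)C)[C@]2(C)OC1=O`: 6300 nM
Compound 2 `CC1(C)[C@H]2CC[C@]1(C)[C@H]1OC(=O)CN=C21`: 135000 nM

Both were tested in a functional assay on MCF7 cells (Homo sapiens) for antiproliferative activity, read by sulforhodamine B assay, with a stated time of 48 h; on this read-out higher numbers stand for weaker inhibition and lower numbers for stronger inhibition. Compound 1 gives 6300 nM, the lower of the two numbers, while compound 2 gives 135000 nM, a gap beyond the usual scatter. Compound 3 `CC(C)(C)OC(=O)NCCCC[C@@H]1N=C2C[C@@H]3C[C@@H](C3(C)C)[C@]2(C)OC1=O` has not yet been measured in this assay. It differs from compound 1 by ((tert-butoxycarbonyl)amino)methyl in place of (tert-butoxycarbonyl)amino on a saturated chain carbon, three bonds along the chain from a saturated ring carbon; nothing else changes. With a single chain carbon added, the step in this assay from compound 1 to compound 3 is expected to be a 1.1-fold lower number from compound 1 to compound 3 (0.02 log units; within the scatter), a change of no size beyond the scatter. Compound 3 is therefore estimated at 6000 nM, in a range from 2000 nM to 20000 nM.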

Compound 3, half-maximal inhibitory concentration: 17000 nM
Compound 3: the middle estimate sits 2.8-fold (0.45 log units) below what was measured, within the range that was stated.
By their numbers in this assay, from the lowest: compound 1; then compound 3; then compound 2.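

In this assay, one added chain carbon is not a silent change: ((tert-butoxycarbonyl)amino)methyl in place of (tert-butoxycarbonyl)amino gives a 2.7-fold higher number from compound 1 to compound 3 (0.43 log units; beyond the scatter), a modest step. This position therefore responds to chain length, and the shorter chain of compound 1 gives the stronger inhibition of this pair. Nothing available explains the step. The compounds shown compare only two chain lengths, so no trend can be drawn from them. From the compounds shown here alone, whether a shorter chain, a longer chain or a free amine at the chain end would give stronger inhibition remains open.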